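Small changes, flat numbers: swapping hydroxy for methyl

This account rests on a few compounds, and the source may have more. Where it says the series, first, only, none or still open, it means among the compounds named here.

compound 1 `O=S(=O)(Nc1ccccc1)c1ccc(I)cc1` gives 23000 nM
compound 2 `CC(C)(C)c1ccc(S(=O)(=O)Nc2ccccc2)cc1` gives 16000 nM
compound 3 `CC(C)(C)c1ccc(S(=O)(=O)Nc2ccc(O)cc2)cc1` gives 14000 nM
compound 4 `Cc1ccc(NS(=O)(=O)c2ccc(C(C)(C)C)cc2)cc1` has not yet been measured

In a functional assay on A549 cells (Homo sapiens) for inhibition (on this read-out lower numbers stand for stronger inhibition of growth and higher numbers for weaker inhibition of growth), compound 3 gives 14000 nM and lies within the scatter of both other compounds, so the three values cannot be put in a reliable order.

The next change swaps one small group for another on compound 3. The 4-hydroxyphenyl becomes 4-methylphenyl, with methyl in place of hydroxy on an aromatic carbon, para to a large group (methyl in place of hydroxy on an aromatic carbon). The tert-butyl group stays as it is.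

Two measured steps offer guidance. The more relevant one changed this same group, with hydroxy in place of hydrogen on an aromatic carbon (a 1.1-fold lower number from compound 2 to compound 3 (0.06 log units; within the scatter)). The other, with tert-butyl in place of iodo on an aromatic carbon, is less direct (a 1.4-fold lower number from compound 1 to compound 2 (0.16 log units; within the scatter)). Both stayed within the scatter. For the measured compounds named here, no measured compound carries methyl on this ring, so the evidence is indirect.

On that basis, no shift beyond the scatter is expected in this assay. The estimated step is small (a 1.1-fold higher number from compound 3 to compound 4 (0.03 log units; within the scatter)). For compound 4 the estimated value is 15000 nM, with an expected range from 7500 nM to 30000 nM.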

Compound 4, concentration for 50% growth inhibition: 11000 nM
For compound 4 the middle estimate is 1.4-fold (0.13 log units) above the measured one; the range from low to high includes it.
By their numbers in this assay, from the lowest: compounds 4, 3, 2 and 1 (each within the scatter of the next, the first and the last beyond it).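

Exchanging the hydroxy of compound 3 for methyl takes away the hydrogen-bond donor and acceptor counted on that group, yet in this assay the step stays within the scatter (a 1.3-fold lower number from compound 3 to compound 4 (0.10 log units; within the scatter)). Putting methyl in place of hydrogen on the same aromatic carbon also stays within the scatter (a 1.5-fold lower number from compound 2 to compound 4 (0.16 log units; within the scatter)), so hydrogen, hydroxy and methyl at this position, para to a large group, give numbers that cannot be told apart, and the presence or absence of that donor and acceptor shows no measurable effect across these compounds. Nothing available here bears on why these three numbers lie so close together.

As far as these compounds go, all three groups compared at this position are small and uncharged, so it remains open whether an amine, a carboxylic acid or a longer chain such as butyl on the same carbon would move the number beyond the scatter. From the compounds shown here alone, it is also open whether the flat result holds only with tert-butyl at the other end of the shared core, since these three comparisons all carry that group.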